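The source may report more compounds than this note shows. Statements on the series, on what has been measured and on what is new or still open speak of the compounds shown alone.

In a functional assay on the whole organism (strain Swiss albino) for inhibition, with Mus musculus as the target, in the writhing test, with stated times of 60 min and 15 min, at a dose of 100 mg/kg by the oral route (a higher number here means more inhibition at the dose given (going by the name of the read-out), a lower number less inhibition), compound 1 `COc1cc2c(cc1OC)C(CC(=O)N(C)C)CC2` gives 22.6%, compound 2 `CCCCCNC(=O)CC1CCc2cc(OC)c(OC)cc21` gives 71.7%, and compound 3 `COc1cc2c(cc1OC)C(CC(=O)NCc1ccccc1)CC2` gives 48.1%. Compound 3 therefore holds the middle of the three numbers: the steps of a number 25.5 percentage points higher from compound 1 to compound 3 (beyond the scatter) and a number 23.6 percentage points lower from compound 2 to compound 3 (beyond the scatter) show it is beyond the scatter from each neighbour. Compound 4 `COc1cc2c(cc1OC)C(CC(=O)N1CCNCC1)CC2` carries the change (piperazin-1-yl in place of benzylamino on a carbonyl carbon). Among the measured compounds shown here, no measured step tests this exact swap. The nearest guides are a number 49.1 percentage points higher from compound 1 to compound 2 (beyond the scatter) and a number 25.5 percentage points higher from compound 1 to compound 3 (beyond the scatter), both large gains when dimethylamino, a nitrogen bearing two carbons, gave way to a nitrogen bearing one carbon. Piperazin-1-yl again attaches through a nitrogen bearing two carbons, so a return toward compound 1 is expected, a fall of a number 18.1 percentage points lower from compound 3 to compound 4 (beyond the scatter). Compound 4 is thus expected to give about 30%, between 10% and 55%.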

Compound 4, a percentage reported as inhibition, in the whole organism at one dose (the size of the read-out at that dose, not a potency): 68.8%
For compound 4 the middle estimate is 38.8 percentage points below the measured one; the measured number lies above the stated range.
By their numbers in this assay, from the lowest: compound 1; then compound 3; then compounds 4 and 2 (each within the scatter of the next).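

On the carbonyl carbon, a nitrogen bearing two carbons need not mean a low number in this assay: piperazin-1-yl in place of dimethylamino gives a number 46.2 percentage points higher from compound 1 to compound 4 (beyond the scatter), and in place of benzylamino it gives a number 20.7 percentage points higher from compound 3 to compound 4 (beyond the scatter). In place of pentylamino it gives a number 2.9 percentage points lower from compound 2 to compound 4 (within the scatter), so this read-out does not separate the ring from the open chain. Nothing available gives a reason for this. Still open, as far as these compounds go, is how piperidin-1-yl or morpholin-4-yl on the same carbonyl carbon would compare with piperazin-1-yl, and how a chain longer than pentylamino would compare with compound 2.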